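A few compounds are considered here, and "the series" means these few. Any claim that something is new, unique, unknown or untested is made for them only; others in the source may bear on it.

Measured so far:
Compound 1 `Cc1nc([C@H](NC(=O)c2ccc(-c3ccc(Cl)c(F)c3)[nH]2)[C@@H]2CCCCN2)sc1CCO`: 16800 nM
Compound 2 `Cc1nc([C@@H](NC(=O)c2ccc(-c3ccc(Cl)cc3)[nH]2)[C@@H]2CCCCN2)sc1CCO`: 26800 nM

Both numbers come from a toxicity assay on MT2 cells (Homo sapiens) for cytotoxicity, read by XTT assay, with a stated time of 4 days; on this read-out higher numbers stand for lower toxicity in this test and lower numbers for higher toxicity in this test. Compound 2, at 26800 nM, lies within the usual scatter of compound 1, so this read-out does not separate the two.

The next compound to consider is compound 3 `Cc1nc([C@H](NC(=O)c2ccc(-c3ccc(Cl)cc3)[nH]2)[C@@H]2CCCCN2)sc1CCO`. Set against compound 2, it differs only in how one centre is drawn: the two compounds have the same atoms and bonds and differ only in configuration as drawn: 1 of 2 stereo elements differ; a stereocentre at a saturated chain carbon is drawn S in compound 2 and R in compound 3. Among the compounds with values here, no measured pair yet shows what such a change in configuration does in this assay, so no step beyond the scatter is expected. Within the data shown here, the only guide is that compound 1, at 16800 nM, and compound 2, at 26800 nM, have values of similar size. The expected change, a 1.1-fold lower number from compound 2 to compound 3 (0.05 log units; within the scatter), stays within the scatter. The estimated value for compound 3 is 24000 nM, with an expected range from 11000 nM to 50000 nM.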

Compound 3, half-maximal cytotoxic concentration: 21000 nM
Beside the measured number, compound 3's estimate is 1.1-fold (0.06 log units) above it, and the stated range covers the measured number.
By their numbers in this assay, from the lowest: compounds 1, 3 and 2 (each within the scatter of the next).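

Drawing one stereocentre at a saturated chain carbon as R instead of S gives a 1.3-fold lower number from compound 2 to compound 3 (0.11 log units; within the scatter) in this assay, so this read-out does not separate the two configurations at that carbon. Hydrogen in place of fluoro on an aromatic carbon gives a 1.3-fold higher number from compound 1 to compound 3 (0.10 log units; within the scatter), so this swap is not separated either. The first comparison isolates configuration alone, as no atom or bond is involved: the fact that compounds 2 and 3 differ only in the configuration as drawn

On these data alone, the second stereo element is drawn the same way in compounds 2 and 3, so what its inversion would do in this test remains open. Also open, as far as these compounds go, is whether a larger group on that aromatic carbon, such as trifluoromethyl or methoxy, or a carboxylic acid in place of the alcohol on the side chain, would give a number beyond the scatter.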